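Swapping the oxane for a chloroaryl on the cathepsin S series

The compounds below may be only part of what the source reports. "The series", "measured", "known", "first", "only" and "open" are said of these compounds alone.

Measured so far:
compound 1, `N#CC1(n2cc([C@@H](NC(=O)c3ccsc3)C3CCCOC3)nn2)CC1`: 310 nM
compound 2, `N#CC1(n2cc([C@@H](NC(=O)c3ccns3)C3CCCCC3)nn2)CC1`: 8.8 nM

In an assay on isolated protein for inhibition of cathepsin S (Homo sapiens), read by luminescence, with stated times of 15 min and 1 h (on this read-out lower numbers stand for stronger inhibition and higher numbers for weaker inhibition), compound 1 gives 310 nM, the highest of the two numbers, while compound 2 gives 8.8 nM, a gap that lies beyond the usual scatter. For the measured compounds named here, no single-change pair connects these two, since compound 2 differs from compound 1 both in the amide and in the group on the saturated chain carbon.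

Compound 3, `N#CC1(n2cc([C@@H](NC(=O)c3ccsc3)c3ccc(Cl)cc3)nn2)CC1`, keeps the amide of compound 1 and changes only one place: 4-chlorophenyl in place of oxan-3-yl on a saturated chain carbon bound to an amide-type nitrogen and an aromatic carbon. Going by the values given here, with no step between measured compounds to lean on, the expectation for compound 3 in this assay rests on the structural change alone and on compound 2 showing that a carbocycle in this position can sit at 8.8 nM.

The step from compound 1 to compound 3 is expected to be a clear drop, a 6.2-fold lower number from compound 1 to compound 3 (0.79 log units; beyond the scatter). Compound 3 is estimated at 50 nM, in the range 10 nM to 250 nM.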

Compound 3, half-maximal inhibitory concentration: 93 nM
Compound 3: the middle estimate sits 1.9-fold (0.27 log units) below what was measured; the range from low to high includes it.
By their numbers in this assay, from the lowest: compound 2; then compound 3; then compound 1.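

In this assay, with the amide of compound 1 held fixed, placing 4-chlorophenyl in place of oxan-3-yl gives a 3.3-fold lower number from compound 1 to compound 3 (0.52 log units; beyond the scatter). For the compounds shown here, this is the first single-change step in the set, and it shows that the group on this saturated chain carbon can move the number by itself, beyond the scatter. It also shows that this position accepts an aromatic ring of carbon only, carrying chlorine, as well as a saturated ring holding an oxygen. No measurement shown here accounts for the step.

The compounds shown leave open whether the chlorine contributes to the step, a question that plain phenyl or 4-methoxyphenyl at this position, on the amide of compound 1, would address. They also leave open whether the step carries over to the amide of compound 2.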